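A few compounds are considered here, and "the series" means these few. Any claim that something is new, unique, unknown or untested is made for them only; others in the source may bear on it.

Compound 1 (`CC(C)(C)NCc1c(C(=O)O)nn(-c2ccccc2)c1-c1ccc(F)cc1`) gives > 680000 nM in a functional assay on K562 cells (Homo sapiens) for inhibition, read by sulforhodamine B assay, with a stated time of 48 h (a lower number here means a stronger inhibitor of growth, a higher number a weaker inhibitor of growth), a limit and not a number. In this assay compound 2 (`CC(C)(C)NCc1c(C(=O)O)nn(-c2ccccc2)c1-c1ccc(Br)cc1`) gives > 585000 nM, also a limit. In this assay compound 3 (`CC(C)(C)NCc1c(C(=O)O)nn(-c2ccc(Cl)cc2)c1-c1ccc(F)cc1`) gives > 623000 nM, again a limit, so compound 3 has no exact place on the scale.

Compound 4 (`CC(C)(C)NCc1c(C(=O)O)nn(-c2ccc(Cl)cc2)c1-c1ccc(Br)cc1`) has not yet been measured. The change leading to it from compound 3 is bromo in place of fluoro on an aromatic carbon, para to a large group. The same replacement has been made once before, in a step that the two limits leave unreadable from compound 1 to compound 2. The addition of chloro in place of hydrogen gives a step that the two limits leave unreadable from compound 1 to compound 3. Neither step has a size that can be carried over, so no step beyond the usual scatter is expected, and compound 4 will probably also be reported only as a limit. The expected step is an at least 1.1-fold lower number from compound 3 to compound 4 (0.06 log units; that floor lies within the scatter). The estimate for compound 4 is 540000 nM, with an expected range from 400000 nM to 700000 nM.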

Compound 4, concentration for 50% growth inhibition: 297000 nM
Compound 4: middle estimate off by 1.8-fold (0.26 log units), on the high side; measured number outside the range, below it.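

In this assay, for the compounds shown here, compound 4 gives the first exact number in this set, and the change from 4-fluorophenyl to 4-bromophenyl, made where chloro is also present, now has a readable size: an at least 2.0-fold lower number from compound 3 to compound 4 (0.32 log units; beyond the scatter). The other new comparison, adding chloro where bromo is already present, gives an at least 1.9-fold lower number from compound 2 to compound 4 (0.29 log units; that floor lies within the scatter), so this floor alone does not establish a role for chloro. Both sizes are floors, and the first is one because compound 3 carries only a limit: the limit of > 623000 nM in this assay, at which 1 of the 4 values shown sits.

On these data alone, the steps from compound 1 to compound 2 and from compound 1 to compound 3 cannot be read, so whether bromo lowers the number without chloro stays open. Also open, as far as these compounds go, is what iodo or methoxy at this place, or a methyl ester in place of the carboxylic acid, would give.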